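Chain shortening on the selenium-bearing position of compound 2

The compounds below may be only part of what the source reports. "The series", "measured", "known", "first", "only" and "open" are said of these compounds alone.

Measured in a functional assay on HTB-54 cells (Homo sapiens) for cytotoxicity, read by MTT assay, with a stated time of 72 h; a higher number here means a weaker inhibitor of growth, a lower number a stronger inhibitor of growth:
compound 1, `CSc1ccc(CNc2nc(SC)nc3ncccc23)cc1`, 14800 nM
compound 2, `CCCCC[Se]c1nc(N)c2ccccc2n1`, 84000 nM
compound 3, `COc1ccc(CNc2nc([SeH])nc3ccccc23)cc1`, 60900 nM

Compound 2 carries the highest number of the three; compound 3 sits within the scatter of it, while compound 1 lies beyond the scatter on the lower side. For the measured compounds named here, no pair among the measured compounds differs in a single place, so no measured step exists.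

Compound 4, `C[Se]c1nc(N)c2ccccc2n1`, is yet to be tested in this assay. It differs from compound 2 by hydrogen in place of butyl on a saturated chain carbon bound to a selenium atom. Going by the values given here, nothing among the measured compounds shows how such a change reads here, so only a small step, expected to lie within the scatter, is taken as the working guess, a 1.1-fold higher number from compound 2 to compound 4 (0.03 log units; within the scatter). Compound 4 is therefore estimated at 90000 nM, between 30000 nM and 250000 nM.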

Compound 4, concentration for total growth inhibition: 88700 nM
Beside the measured number, compound 4's estimate is 1.0-fold (0.01 log units) above it; the range from low to high includes it.
By their numbers in this assay, from the lowest: compound 1; then compounds 3, 2 and 4 (each within the scatter of the next).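

In this assay, hydrogen in place of butyl on a saturated chain carbon bound to a selenium atom gives a 1.1-fold higher number from compound 2 to compound 4 (0.02 log units; within the scatter) and so separates the two compounds by no more than repeated measurements would. Across this pair, pentyl and methyl on the selenium atom therefore read alike, which the earlier compounds, lacking any one-place pair, could not show. This holds for these two chain lengths only.

On these data alone, whether a longer chain, or an amine or carboxylic acid on the chain, would read differently remains open. No measurement shown accounts for this result.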